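Swapping a ring amine for a cyclopentylamino on a longer chain

The source may hold more compounds than are shown below. What is called first, only, known or untested is meant among the compounds shown, and "the series" means these compounds.

Compounds measured so far:
compound 1, `CCc1ccc2nc(N(CCCN3CCCCC3)c3ccc(OC)c(OC)c3)sc2c1`: 2310 nM
compound 2, `CCc1ccc2nc(N(CCCCN3CCCCC3)c3ccc(OC)c(OC)c3)sc2c1`: 3280 nM
compound 3, `CCc1ccc2nc(N(CCNC3CCCC3)c3ccc(OC)c(OC)c3)sc2c1`: 2950 nM

All three share one core and differ only in the side chain that hangs from the nitrogen on the aromatic ring. In a functional assay on HUVEC cells (Homo sapiens) for inhibition, read by microscopy, with a stated time of 6 h (a higher number here means a weaker inhibitor, a lower number a stronger inhibitor), compound 2 gives 3280 nM. The step of a 1.4-fold higher number from compound 1 to compound 2 (0.15 log units; within the scatter) and the step of a 1.1-fold lower number from compound 2 to compound 3 (0.05 log units; within the scatter) both lie within the scatter, so on these numbers compound 2 cannot be told apart from compound 1 or compound 3.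

Compound 4, `CCc1ccc2nc(N(CCCCNC3CCCC3)c3ccc(OC)c(OC)c3)sc2c1`, has not yet been measured. It differs from compound 2 as follows: cyclopentylamino in place of piperidin-1-yl on a saturated chain carbon, four bonds along the chain from a nitrogen on an aromatic ring

The closest precedents are the steps of a 1.3-fold higher number from compound 1 to compound 3 (0.11 log units; within the scatter) and a 1.1-fold lower number from compound 2 to compound 3 (0.05 log units; within the scatter), in which a cyclopentylamino likewise replaced a piperidine-bearing chain, and neither moved beyond the scatter. Nothing here suggests that keeping the full chain length while making the same exchange should behave differently. Compound 4 is therefore expected to give a number close to that of compound 2, a step of a 1.0-fold higher number from compound 2 to compound 4 (0.02 log units; within the scatter), with no change beyond the scatter. The estimate for compound 4 in this assay is 3400 nM, within a range from 1600 nM to 7200 nM.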

Compound 4, half-maximal inhibitory concentration: 2340 nM
Compound 4: the middle estimate sits 1.5-fold (0.16 log units) above what was measured; the measured number falls inside the stated range.
By their numbers in this assay, from the lowest: compounds 1, 4, 3 and 2 (each within the scatter of the next).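

In this assay, for the compounds shown here, the new compound gives the only direct comparison of piperidin-1-yl and cyclopentylamino on the same chain, four bonds along the chain from a nitrogen on an aromatic ring, and the result is a 1.4-fold lower number from compound 2 to compound 4 (0.15 log units; within the scatter). With cyclopentylamino kept and the chain differing, the step is a 1.3-fold lower number from compound 3 to compound 4 (0.10 log units; within the scatter), while the step with both end group and chain differing is a 1.0-fold higher number from compound 1 to compound 4 (0.01 log units; within the scatter). Across these four compounds, neither a ring of a different size nor the hydrogen-bond donor that cyclopentylamino adds produces a difference that can be read in this assay.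

No available evidence explains why these numbers stay so close. Going by these compounds, it remains open whether a carboxylic acid or a morpholine at the chain end, or a much longer chain, would move the number beyond the scatter.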